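A few compounds are considered here, and "the series" means these few. Any claim that something is new, unique, unknown or untested is made for them only; others in the source may bear on it.

Within the data shown here, in a functional assay on SW480 cells (Homo sapiens) for antiproliferative activity, read by MTT assay, with a stated time of 48 h (a higher number here means a weaker inhibitor, a lower number a stronger inhibitor), compound 1 `CC(=O)OC/C1=C/C[C@](C)(CCC=C(C)C)/C=C/[C@@H](OC(=O)C=C(C)C)[C@](C)(O)/C=C/C1=O` gives 2950 nM and compound 2 `CC(C)=CCC[C@]1(C)/C=C/[C@@H](OC(=O)C=C(C)C)[C@](C)(O)/C=C/C(=O)/C(CN2CCCC2)=C\C1` gives 310 nM, which makes compound 2 the lower of the two numbers measured so far. Compound 3 `CC(C)=CCC[C@]1(C)/C=C/[C@@H](OC(=O)C=C(C)C)[C@](C)(O)/C=C/C(=O)/C(CN2CCN(C)CC2)=C\C1` keeps the shared core and differs from compound 2 in one place: 4-methylpiperazin-1-yl in place of pyrrolidin-1-yl on a saturated chain carbon bound to a double-bonded ring carbon. Here, 4-methylpiperazin-1-yl stands in place of pyrrolidin-1-yl on a saturated chain carbon bound to a double-bonded ring carbon. Among the measured compounds shown here, only one measured step bears on this change, and it lies at the same carbon: pyrrolidin-1-yl in place of acetoxy gave a 9.5-fold lower number from compound 1 to compound 2 (0.98 log units; beyond the scatter). For the measured compounds named here, that step shows that the number in this assay can move with the group at this place, but no measured pair compares pyrrolidin-1-yl with another ring group. A shift as large as that step is therefore not expected, and a smaller move toward a higher number seems more likely. The estimated change is a 1.5-fold higher number from compound 2 to compound 3 (0.16 log units; within the scatter). Compound 3 is expected at about 450 nM in this assay, with an estimated range of 140 nM to 1500 nM.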

Compound 3, half-maximal inhibitory concentration: 800 nM
Compound 3: middle estimate off by 1.8-fold (0.25 log units), on the low side, within the range that was stated.
By their numbers in this assay, from the lowest: compound 2; then compound 3; then compound 1.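

In this assay, the ring group at this place proves to matter, and not only its presence in place of acetoxy: 4-methylpiperazin-1-yl in place of pyrrolidin-1-yl gives a 2.6-fold higher number from compound 2 to compound 3 (0.41 log units; beyond the scatter) and so separates two groups that the earlier pair could not compare. Measured against acetoxy, the new group still gives a 3.7-fold lower number from compound 1 to compound 3 (0.57 log units; beyond the scatter) in the same direction as a 9.5-fold lower number from compound 1 to compound 2 (0.98 log units; beyond the scatter) and thus both ring groups stand on the same side of acetoxy, with compound 2 lowest of the three. No evidence at hand accounts for the difference between the two ring groups.

The compounds shown leave open which part of the change carries the shift, since the six-membered ring, the second ring nitrogen and its methyl all enter together. Piperidin-1-yl, morpholin-4-yl or piperazin-1-yl without the methyl would begin to separate these parts, and an open-chain amine such as dimethylamino would show whether a ring is needed at this saturated chain carbon at all.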